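A few compounds are considered here, and "the series" means these few. Any claim that something is new, unique, unknown or untested is made for them only; others in the source may bear on it.

Compound 1 `O=C(O)Cc1sc(Cc2ccc(Cl)cc2)nc1-c1ccccc1` is the starting point of this account. In an in vitro functional assay on HEK285-7 cells for antagonist activity at prostaglandin D2 receptor 2 (Homo sapiens), read by BRET and beta-arrestin recruitment (a lower number here means a smaller maximal response, a higher number a larger maximal response), compound 1 gives > 70%, and this is a limit of the assay rather than a number. Compound 2 `O=C(O)Cc1sc(Cc2ccc(Cl)cc2)nc1-c1ccc(Cl)cc1` carries chloro in place of hydrogen on an aromatic carbon of compound 1. In this assay compound 2 gives > 70%, again a limit. Compound 3 `COc1ccc(-c2nc(Cc3ccc(Cl)cc3)sc2CC(=O)O)cc1` carries methoxy in place of hydrogen on the same kind of aromatic carbon. In this assay compound 3 gives > 70%, which is likewise a limit. The three comparisons among them are a step that the two limits leave unreadable from compound 1 to compound 2, a step that the two limits leave unreadable from compound 1 to compound 3 and a step that the two limits leave unreadable from compound 2 to compound 3, so none of them yields a readable size. What they do share is the limit of > 70% in this assay, at which 3 of the 3 values shown sit.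

Compound 4 `Cc1ccc(Cc2nc(-c3ccccc3)c(CC(=O)O)s2)cc1` is not yet measured. It differs from compound 1 as follows: methyl in place of chloro on an aromatic carbon. For the measured compounds named here, no measured step covers a methyl in place of chloro on an aromatic carbon. Because the limit of > 70% in this assay, at which 3 of the 3 values shown sit, holds for every measured compound, the expected step in this assay is a step that the limit leaves unreadable from compound 1 to compound 4, with no readable direction. For compound 4 the estimate in this assay is 85%, expected to lie between 70% and 100%.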

Compound 4, largest response reached (reported as efficacy), in percent of the reference or control that the assay uses: > 70%
Compound 4: a limit, no number; the forecaster's own chance of this, stated with the estimate: 80%; the middle value is on the limit's open side.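

In this assay compound 4 gives > 70%, which is a limit and not a number. For the compounds shown here, compound 1 also stands only at a limit, so no step from compound 1 to compound 4 can be read. The compounds shown leave open how large the maximal response of each actually is, and whether any of these changes alters it: the limit of > 70% in this assay, at which 4 of the 4 values shown sit.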